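Urea aryl methylation in an indolylthio-pyrimidine series

This account rests on a few compounds, and the source may have more. Where it says the series, first, only, none or still open, it means among the compounds named here.

Compound 1 `O=C(Nc1ccccc1)Nc1nc(Sc2c[nH]c3ccccc23)cc(N2CCN(Cc3ccccc3)CC2)n1` is the reference point. In a functional assay on MDA-MB-231 cells (Homo sapiens) for inhibition, with a stated time of 72 h (a higher number here means a weaker inhibitor, a lower number a stronger inhibitor), compound 1 gives 10200 nM, and compound 2 `O=C(Nc1ccccc1)Nc1nc(Sc2c[nH]c3ccccc23)cc(N2CCN(c3ccccn3)CC2)n1` gives 19500 nM. Within the data shown here, the one measured step, a 1.9-fold higher number from compound 1 to compound 2 (0.28 log units; within the scatter), lies within the scatter, so the two measured compounds are not separated by these numbers and neither can be called the stronger.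

Compound 3 `Cc1ccc(C)c(NC(=O)Nc2nc(Sc3c[nH]c4ccccc34)cc(N3CCN(Cc4ccccc4)CC3)n2)c1` differs from compound 1 at the urea: 2,5-dimethylphenyl in place of phenyl on an amide-type nitrogen. Among the measured compounds shown here, no measured step touches this part of the molecule; the step from compound 1 to compound 2 changes the amine substituent of the ring instead and therefore gives no guidance on the urea aryl. For the measured compounds named here, with nothing beyond the scatter seen in this assay so far, the expectation for compound 3 is a step of a 1.0-fold lower number from compound 1 to compound 3 (0.01 log units; within the scatter), that is, no change beyond the scatter. The estimate for compound 3 in this assay is 10000 nM, within 3500 nM to 30000 nM.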

Compound 3, half-maximal inhibitory concentration: 19000 nM
Beside the measured number, compound 3's estimate is 1.9-fold (0.28 log units) below it; low and high end bracket the measured number.
By their numbers in this assay, from the lowest: compounds 1, 3 and 2 (each within the scatter of the next).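

The urea aryl now has its own reading: 2,5-dimethylphenyl in place of phenyl on the amide-type nitrogen gives a 1.9-fold higher number from compound 1 to compound 3 (0.27 log units; within the scatter) in this assay, so compound 1 and compound 3 are not separated by these numbers. This position therefore tolerates an aryl group of 8 heavy atoms in place of one of 6, with no difference beyond the scatter. Nothing on hand accounts for this reading. 

Going by these compounds, it remains open whether a urea aryl carrying a carboxylic acid, an amine or a methoxy group, or a cyclohexyl group in place of the aryl, would give a step beyond the scatter. Also open, on these data alone, is how 2,5-dimethylphenyl on the urea behaves with pyridin-2-yl on the amine nitrogen in the ring.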